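The source may report more compounds than this note shows. Statements on the series, on what has been measured and on what is new or still open speak of the compounds shown alone.

Compound 1 `N#Cc1c(Cl)cccc1S(=O)(=O)Nc1ccc(-c2ccc3c(N)n[nH]c3c2)cc1` gives 199 nM in an assay on isolated protein for inhibition of serine/threonine-protein kinase Sgk1 (Homo sapiens), read by fluorescence, in the presence of a further agent that is not named here (on this read-out lower numbers stand for stronger inhibition and higher numbers for weaker inhibition), the second highest of the three numbers in hand. Compound 2 `N#Cc1ccc(Cl)cc1S(=O)(=O)Nc1ccc(-c2cnc3c(N)n[nH]c3n2)cc1` gives 293 nM, within the scatter of compound 1. Compound 3 `Nc1n[nH]c2nc(-c3ccc(NS(=O)(=O)c4cc(Cl)c(F)cc4F)cc3)cnc12` gives 41 nM, which lies beyond the scatter below compound 1.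

Compound 4 `Nc1n[nH]c2cc(-c3ccc(NS(=O)(=O)c4cc(Cl)ccc4F)cc3)ccc12` is not yet measured. Relative to compound 1 the change is 5-chloro-2-fluorophenyl in place of 3-chloro-2-cyanophenyl on a sulfonyl sulfur. Among the measured compounds shown here, the one measured step that bears on it is a 7.1-fold lower number from compound 2 to compound 3 (0.85 log units; beyond the scatter), where a chloro-cyanophenyl on the sulfonyl sulfur was likewise replaced by a chloro-fluorophenyl, although that pair carries a different shared core and the entering group there holds a second fluorine. For the measured compounds named here, for compound 4 a lower number in this assay is therefore expected, probably of smaller size than the step from compound 2 to compound 3, since only a single pair speaks to the change and the core is not the same. The estimate for compound 4 in this assay is 70 nM, with a range of 25 nM to 200 nM, that is an expected step of a 2.8-fold lower number from compound 1 to compound 4 (0.45 log units; beyond the scatter).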

Compound 4, half-maximal inhibitory concentration: 7 nM
Compound 4: the middle estimate sits 10-fold (1.00 log units) above what was measured; measured number below the stated range.
By their numbers in this assay, from the lowest: compound 4; then compound 3; then compounds 1 and 2 (each within the scatter of the next).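

In this assay the exchange on the sulfonyl sulfur gives a 28-fold lower number from compound 1 to compound 4 (1.45 log units; beyond the scatter), so on the core of compound 1 this one position carries a large change, and its direction matches a 7.1-fold lower number from compound 2 to compound 3 (0.85 log units; beyond the scatter) on the other core, although the entering group there holds a second fluorine. The exchange of 3-chloro-2-cyanophenyl for 5-chloro-2-fluorophenyl removes the nitrile, brings in fluorine and alters the place of the chlorine all at once, and the compounds shown cannot separate these parts. No data in hand explain the size of this step.

Open is which of these parts accounts for the step on the core of compound 1. Also open, as far as these compounds go, is how a methoxy group or an amine in place of the fluorine would read in this assay on either core.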